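Replacing an aryl urea tail with a diethyl urea

The compounds below may be only part of what the source reports. "The series", "measured", "known", "first", "only" and "open" are said of these compounds alone.

Measured compounds:
- compound 1, `CN(C)C(=O)c1cccc(NC(=O)NCc2cccc(N3C(N)=NC(N)=NC3(C)C)c2)c1`: 7.77
- compound 2, `CC1(C)N=C(N)N=C(N)N1c1cccc(CNC(=O)Nc2cccc([N+](=O)[O-])c2)c1`: 8.1
- compound 3, `CC1(C)N=C(N)N=C(N)N1c1ccc(CCCCc2cc(Cl)ccc2S(=O)(=O)F)c(Cl)c1`: 7.06

All three compounds were tested in an assay on isolated protein for inhibition of Dihydrofolate reductase (Mus musculus); on this read-out lower numbers stand for lower potency and higher numbers for higher potency (the scale is a negative logarithm). Compound 2 stands highest of the three numbers. Its nearest neighbour is compound 1, whose value lies lower by a number 0.33 log units higher from compound 1 to compound 2 (beyond the scatter), a step that swaps nitro for dimethylcarbamoyl on an aromatic carbon. Among the measured compounds shown here, the furthest is compound 3, whose value is lower still, but compound 3 differs from compound 2 in several places at once, so no single step between them can be drawn.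

The unmeasured compound 4, `CCN(CC)C(=O)NCc1cccc(N2C(N)=NC(N)=NC2(C)C)c1`, differs from compound 2 in one place: diethylamino in place of (3-nitrophenyl)amino on a carbonyl carbon. For the measured compounds named here, the one measured step only changes a substituent on that aryl ring, whereas here the whole (3-nitrophenyl)amino group is gone and a diethylamino group takes its place on the carbonyl carbon. Going by the values given here, nothing among the measured compounds shows the effect of removing that ring. The comparison with compound 3, which also lacks such a tail and sits well below compound 2, hints at a loss. A step downward in this assay is therefore expected for compound 4, of about a number 1.10 log units lower from compound 2 to compound 4 (beyond the scatter). Compound 4 is estimated at 7, with a range from 6.3 to 7.7.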

Compound 4, logarithm of the reciprocal of the active concentration, log(1/C): 6.11
Compound 4: the middle estimate sits 0.89 log units above what was measured; the whole stated range lies above it.
By their numbers in this assay, from the lowest: compound 4; then compound 3; then compound 1; then compound 2.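

In this assay, the group on the carbonyl carbon proves far more sensitive than the earlier change on the aryl ring suggested: the step from diethylamino replacing (3-nitrophenyl)amino is large (a number 1.99 log units lower from compound 2 to compound 4 (beyond the scatter)), whereas the swap of dimethylcarbamoyl for nitro on that ring was modest (a number 0.33 log units higher from compound 1 to compound 2 (beyond the scatter)). This exchange changes several things at once, since the leaving group brings an aromatic ring, more heavy atoms and a hydrogen-bond donor, while diethylamino has no ring and no donor, so this single pair cannot show which of these differences matters. No measurement at hand explains the size of the step.

From the compounds shown here alone, it remains open whether the loss follows the ring or the hydrogen on the nitrogen: a cyclohexylamino group would keep a ring that is not aromatic, and an ethylamino group would keep that hydrogen with no ring at all. The compounds shown also leave open where a plain phenylamino group, with no nitro on its ring, would stand on this scale.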